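Swapping a Chlorophenyl for Thiophene on a Shared Core

The compounds below may be only part of what the source reports. "The series", "measured", "known", "first", "only" and "open" are said of these compounds alone.

Of the compounds shown here, two built on the same core have been tested in a functional assay on SNB-75 cells (Homo sapiens) for inhibition, read by sulforhodamine B assay, with a stated time of 48 h, tested at 10 uM; a lower number here means less inhibition, a higher number more inhibition at the concentration tested (going by the name of the read-out). Compound 1 `O=Cc1ccc(-c2cn3ccnc3c(-c3ccc4ncn(C5CCCCC5)c4c3)n2)cc1` gives 21.4% in this assay. Compound 2 `Clc1ccc(-c2cn3ccnc3c(-c3ccc4ncn(C5CCCCC5)c4c3)n2)cc1` gives 31.2% in this assay. Among the compounds with values here, the only step so far, a number 9.8 percentage points higher from compound 1 to compound 2 (within the scatter), means compound 2 cannot be ranked against compound 1; the two readings are indistinguishable once the scatter is taken into account.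

Compound 3 `c1csc(-c2cn3ccnc3c(-c3ccc4ncn(C5CCCCC5)c4c3)n2)c1` has not yet been measured. Its difference from compound 2 is thiophen-2-yl in place of 4-chlorophenyl on an aromatic carbon. Within the data shown here, the one measured step concerns chloro in place of formyl and does not involve a thiophen-2-yl group, so no measured step bears on this change directly. Among the measured compounds shown here, the only guidance is that one swap of a group at this position moved the reading by less than the scatter.

On that basis, compound 3 is expected to stay near the reading of compound 2, a step of a number 6.2 percentage points lower from compound 2 to compound 3 (within the scatter). The estimate for compound 3 in this assay is 25%, with a range from 5% to 45%, and the uncertainty is wide because nothing measured here involves thiophene.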

Compound 3, a percentage reported as inhibition, at one concentration (the size of the read-out at that concentration, not a potency): 8.13%
For compound 3 the middle estimate is 16.9 percentage points above the measured one; the measured number falls inside the stated range.
By their numbers in this assay, from the lowest: compound 3; then compounds 1 and 2 (each within the scatter of the next).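

In this assay, thiophen-2-yl in place of 4-chlorophenyl gives a number 23.1 percentage points lower from compound 2 to compound 3 (beyond the scatter), and thiophen-2-yl in place of 4-formylphenyl gives a number 13.3 percentage points lower from compound 1 to compound 3 (beyond the scatter). This position on the shared core is therefore not indifferent to the group it carries: the two substituted six-membered rings of compound 1 and compound 2 cannot be told apart, while the five-membered sulfur-containing ring of compound 3 sits lowest of the three, though the steps are modest and rest on these compounds alone. Nothing given here explains why this swap lowers the reading.

The swap changes two things at once, the ring itself and the substituent on it, so a plain phenyl group or a thiophen-2-yl ring carrying a chloro would be needed to separate the two. From the compounds shown here alone, it also remains open whether a different five-membered ring, such as furan-2-yl, or a six-membered ring carrying an amine would follow compound 3 or stay level with compound 1 and compound 2, and each reading here is a single concentration rather than a potency.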